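A few compounds are considered here, and "the series" means these few. Any claim that something is new, unique, unknown or untested is made for them only; others in the source may bear on it.

Going by the values given here, compound 2, `C=CCc1cc(C(C)=O)c(O)cc1OCCCCC`, stands highest of the two compounds measured so far in an assay on isolated protein for inhibition of leukotriene B4 receptor 1 (Homo sapiens), tested at 10 uM (a higher number here means more inhibition at the concentration tested (going by the name of the read-out), a lower number less inhibition), with a reading of 60%. Among the compounds with values here, its only neighbour on this scale is compound 1, `C=CCc1cc(C(C)=O)c(O)cc1OCCCC#N`, which in this assay gives 47%. Within the data shown here, the single measured step between them, a number 13 percentage points higher from compound 1 to compound 2 (beyond the scatter), is the only guide available for the next change.

Compound 3, `C=CCc1cc(C(C)=O)c(O)cc1OCCCCO`, differs from compound 2 in one place: hydroxy in place of methyl on a saturated chain carbon, four bonds along the chain from an oxygen on an aromatic ring. The group that leaves carries no hydrogen-bond donor or acceptor; the hydroxy that enters brings one of each. The measured step went the other way in kind, swapping a cyano for ethyl at a nearby chain position, and it moved the reading up by a modest amount. A change that reinstalls a donor and acceptor at the chain end is therefore expected to move the reading down by a comparable amount, a number 13 percentage points lower from compound 2 to compound 3 (beyond the scatter), though with one step to lean on the direction is far from certain. Compound 3 is estimated to give 47% in this assay, within a range from 30% to 64%.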

Compound 3, a percentage reported as inhibition, at one concentration (the size of the read-out at that concentration, not a potency): 48%
Compound 3: the middle estimate sits 1 percentage points below what was measured; the measured number falls inside the stated range.
By their numbers in this assay, from the lowest: compounds 1 and 3 (each within the scatter of the next); then compound 2.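

With hydroxy in place of methyl on a saturated chain carbon, four bonds along the chain from an oxygen on an aromatic ring, this assay shows a number 12 percentage points lower from compound 2 to compound 3 (beyond the scatter), so the chain of compound 2, which ends in plain carbon, now reads beyond the scatter above two different replacements at this end of the chain, and none of the three compounds goes against this. The nitrile and the hydroxy cannot be told apart in this assay, as the change of hydroxymethyl in place of cyano gives a number 1 percentage points higher from compound 1 to compound 3 (within the scatter), which means that two different groups at this end of the chain give readings that match within the scatter. No supporting measurement bears on this result, so the shift cannot be tied to any particular property of these groups.

Still open, as far as these compounds go, is how an amine or a carboxylic acid at the end of the chain would read, and whether either would fall with compound 1 and compound 3 or with compound 2. A longer chain ending in plain carbon would show whether the reading can climb further than that of compound 2 in this series.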